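The compounds below may be only part of what the source reports. "The series", "measured", "known", "first", "only" and "open" are said of these compounds alone.

Series notes. Compound 1 `N#CC1=C(N)Oc2c(N)cc3nc4ccccc4nc3c2C12C(=O)N(Cc1cnnn1-c1cccc(C(F)(F)F)c1)c1ccccc12` in an ADME assay on HUVEC cells (Homo sapiens) for antiproliferative activity, read by MTT assay, with a stated time of 48 h (a higher number here means a weaker inhibitor, a lower number a stronger inhibitor), gives > 50000 nM, which is a limit of the assay and not a number. Compound 2 `COc1ccccc1-n1nncc1CN1C(=O)C2(C(C#N)=C(N)Oc3c(N)cc4nc5ccccc5nc4c32)c2ccccc21` likewise gives in this assay > 50000 nM, again a limit. Compound 3 `Cc1cc(C)cc(-n2nncc2CN2C(=O)C3(C(C#N)=C(N)Oc4c(N)cc5nc6ccccc6nc5c43)c3ccccc32)c1` gives in this assay > 50000 nM, also a limit, so compound 3 stands where every measured member stands (the limit of > 50000 nM in this assay, at which 3 of the 3 values shown sit). The measured steps a step that the two limits leave unreadable from compound 1 to compound 2, a step that the two limits leave unreadable from compound 1 to compound 3 and a step that the two limits leave unreadable from compound 2 to compound 3 are accordingly unreadable in size. Compound 4 `N#CC1=C(N)Oc2c(N)cc3nc4ccccc4nc3c2C12C(=O)N(Cc1cnnn1-c1cc(Cl)ccc1Cl)c1ccccc12` differs from compound 3 by 2,5-dichlorophenyl in place of 3,5-dimethylphenyl on an aromatic nitrogen. All three steps bear on this change, each exchanging the phenyl group on the aromatic nitrogen, yet none gives a size. Compound 4 in this assay is expected at 60000 nM, range 20000 nM to 200000 nM, most likely again reported only as a limit. The step that the limit leaves unreadable from compound 3 to compound 4 is expected to be none beyond the scatter.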

Compound 4, half-maximal inhibitory concentration: > 50000 nM
Compound 4 gave a limit, no number; the forecaster's own chance of this, stated with the estimate: 85%; the middle value is on the limit's open side.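

Compound 4 is again only a limit of the assay, so its steps from compound 1, compound 2 and compound 3 cannot be read in this assay: the limit of > 50000 nM in this assay, at which 4 of the 4 values shown sit.

The compounds shown leave open how these four substituted phenyl groups rank, and whether any group in this place gives a measurable value.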